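The source may hold more compounds than are shown below. What is called first, only, known or untested is meant among the compounds shown, and "the series" means these compounds.

Measured compounds:
compound 1, `COc1ccc(CSc2nnc(-c3cc(OC)c(OC)c(OC)c3)n2-c2ccc(OC)cc2)cc1`, 41100 nM
compound 2, `COc1ccc(C(=O)CSc2nnc(-c3cc(OC)c(OC)c(OC)c3)n2-c2ccc(OC)cc2)cc1`, 18100 nM
compound 3, `COc1ccc(-n2c(SCC(=O)C3CC3)nnc2-c2cc(OC)c(OC)c(OC)c2)cc1`, a limit, > 60000 nM

In a functional assay on HepG2 cells (Homo sapiens) for inhibition, read by MTT assay, with a stated time of 48 h (a higher number here means a weaker inhibitor, a lower number a stronger inhibitor), compound 2 gives 18100 nM, the lowest of the two numbers shown. Compound 1 gives 41100 nM, and the step of a 2.3-fold lower number from compound 1 to compound 2 (0.36 log units; beyond the scatter) is modest. Compound 3 reaches only a limit, > 60000 nM. Compound 4, `COc1ccc(C(=O)CSc2nnc(-c3cc(OC)c(OC)c(OC)c3)n2-c2ccc(N(C)C)cc2)cc1`, differs from compound 2 as follows: dimethylamino in place of methoxy on an aromatic carbon. Among the compounds with values here, none of the measured steps touches this aromatic carbon; they all change the group on the saturated chain carbon bound to sulfur or on the carbonyl carbon, as in an at least 3.3-fold higher number from compound 2 to compound 3 (0.52 log units; beyond the scatter). With nothing bearing on the change, no shift beyond the scatter is expected, and compound 4 is thus expected to come out with a 1.0-fold lower number from compound 2 to compound 4 (0.00 log units; within the scatter). Compound 4 is estimated at 18000 nM, between 6000 nM and 50000 nM.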

Compound 4, half-maximal inhibitory concentration: 18800 nM
Compound 4: the middle estimate sits 1.0-fold (0.02 log units) below what was measured; measured number inside the range.
By their numbers in this assay, from the lowest: compounds 2 and 4 (each within the scatter of the next); then compound 1. At a limit, above all of these: compound 3.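

In this assay, within the data shown here, the first step at this aromatic carbon, para to a large group, puts dimethylamino in place of methoxy and reads as a 1.0-fold higher number from compound 2 to compound 4 (0.02 log units; within the scatter) and so shows no shift. At this position, then, the two groups cannot be told apart in this assay, unlike the changes on the chain. Nothing at hand bears on why they read alike. On these data alone, whether a carboxylic acid or a primary amine at this carbon would move the number stays open. So does whether dimethylamino would read the same on the chain of compound 1.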